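This account rests on a few compounds, and the source may have more. Where it says the series, first, only, none or still open, it means among the compounds named here.

Series notes. Within the data shown here, compound 1 `CC(=O)NC[C@H]1CN(c2ccc(OC[C@@H](O)CNc3ccccc3)c(F)c2)C(=O)O1` carries the anilino group; in a physicochemical assay for lipophilicity, read by HPLC (a higher number here means a more lipophilic compound, a lower number a more polar compound), compound 1 gives 1.42, the highest of the three numbers so far. Compound 2 `CC(=O)NC[C@H]1CN(c2ccc(OC[C@@H](O)CNc3ccccn3)c(F)c2)C(=O)O1` gives 1.37, and compound 3 `CC(=O)NC[C@H]1CN(c2ccc(OC[C@@H](O)CNc3cccnc3)c(F)c2)C(=O)O1` gives 0.02. The step of a number 0.05 log units lower from compound 1 to compound 2 (within the scatter) sits within the scatter, whereas a number 1.40 log units lower from compound 1 to compound 3 (beyond the scatter) and a number 1.35 log units lower from compound 2 to compound 3 (beyond the scatter) are large. Compound 4 `CC(=O)NC[C@H]1CN(c2ccc(OC[C@@H](O)CNCCC(C)C)c(F)c2)C(=O)O1` is not yet measured. It differs from compound 1 as follows: isopentyl in place of phenyl on an amine nitrogen. Among the measured compounds shown here, no measured step exchanges the phenyl for a chain, so the pyridyl steps bear only indirectly; they show that the number can move a long way with a modest change at this amine nitrogen. In this assay a decrease beyond the scatter is expected, a number 0.82 log units lower from compound 1 to compound 4 (beyond the scatter), with compound 4 estimated at 0.6 (range 0 to 1.2).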

Compound 4, partition coefficient: 1.17
For compound 4 the middle estimate is 0.57 log units below the measured one; measured number inside the range.
By their numbers in this assay, from the lowest: compound 3; then compounds 4, 2 and 1 (each within the scatter of the next).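

With the isopentyl chain on the amine nitrogen, the step of a number 0.25 log units lower from compound 1 to compound 4 (within the scatter) and the step of a number 0.20 log units lower from compound 2 to compound 4 (within the scatter) show that an aromatic ring is not needed at this position for the number in this assay to stay at this level. Compound 3 goes against this level alone, with the step of a number 1.15 log units higher from compound 3 to compound 4 (beyond the scatter) setting it apart from the chain as well as from the other aromatic groups. No available evidence accounts for these results. Open, going by these compounds, are a longer chain, a chain ending in a carboxylic acid, and whether pyridin-4-yl would sit with compound 3 or with compound 2.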